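A Methoxy Group Added to an Even Series

The compounds below may be only part of what the source reports. "The series", "measured", "known", "first", "only" and "open" are said of these compounds alone.

In a functional assay on A549 cells (Homo sapiens) for antiproliferative activity, read by sulforhodamine B assay, with a stated time of 48 h (a higher number here means a weaker inhibitor, a lower number a stronger inhibitor), compound 1 (`COc1ccc(C[C@@H](O)/C=C/C=C/C(=O)NCc2ccc(Cl)cc2)cc1OC`) gives 16500 nM, compound 2 (`CCN1CCN(C(=O)/C=C/C=C/[C@H](O)Cc2ccc(OC)c(OC)c2)CC1`) gives 15700 nM and compound 3 (`COc1ccc(C[C@@H](O)/C=C/C=C/C(=O)NCc2ccccc2)cc1OC`) gives 17100 nM. These three values lie within the scatter of one another, so compound 3 cannot be separated from either of the other two compounds.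

The next compound, compound 4 (`COc1ccc(CNC(=O)/C=C/C=C/[C@H](O)Cc2ccc(OC)c(OC)c2)cc1`), is built from compound 3 by one change: methoxy in place of hydrogen on an aromatic carbon. Methoxy takes the place of hydrogen on an aromatic carbon, para to a large group, which turns benzyl into 4-methoxybenzyl.

The closest measured evidence is the exchange of chloro for hydrogen on an aromatic carbon, a 1.0-fold higher number from compound 1 to compound 3 (0.02 log units; within the scatter). A much larger exchange at the carbonyl carbon also left the value within the scatter, a 1.1-fold lower number from compound 1 to compound 2 (0.02 log units; within the scatter), and the same holds for a 1.1-fold higher number from compound 2 to compound 3 (0.04 log units; within the scatter). Among the compounds with values here, no measured compound carries a methoxy group on this benzyl ring, so this evidence is indirect. Given these three small steps, no shift beyond the scatter is expected in this assay.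

The estimated change is a 1.1-fold lower number from compound 3 to compound 4 (0.03 log units; within the scatter). Compound 4 is expected to give 16000 nM, with an estimated range from 8000 nM to 32000 nM.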

Compound 4, half-maximal inhibitory concentration: 16800 nM
Compound 4: middle estimate off by 1.1-fold (0.02 log units), on the low side, and the stated range covers the measured number.
By their numbers in this assay, from the lowest: compounds 2, 1, 4 and 3 (each within the scatter of the next).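

The result extends a flat picture at this position. In this assay, the methoxy group on an aromatic carbon, para to a large group, brings no separable change (a 1.0-fold lower number from compound 3 to compound 4 (0.01 log units; within the scatter)), so compound 4 cannot be told from the compound with the unsubstituted benzyl group. Exchanging chloro for methoxy at the same place is equally unresolved (a 1.0-fold higher number from compound 1 to compound 4 (0.01 log units; within the scatter)), which means that hydrogen, chloro and methoxy, across compounds 3, 1 and 4, all give values within the scatter of one another, and nothing shown accounts for this lack of response.

From the compounds shown here alone, it remains open whether any group at this position can move the value beyond the scatter, such as a carboxylic acid, an amine or a longer alkoxy chain, or whether a substituent placed elsewhere on the benzyl ring would behave differently. Going by these compounds, the dimethoxyphenyl end, the hydroxyl-bearing carbon and the diene chain are the same in all four compounds, so what these parts of the shared core contribute to the activity also stays unknown.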